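A few compounds are considered here, and "the series" means these few. Any claim that something is new, unique, unknown or untested is made for them only; others in the source may bear on it.

Compound 1, `CC(CSc1ccc(C(F)(F)F)cc1)(Sc1ccc(C(F)(F)F)cc1)C(=O)Nc1ccc(C#N)c(C(F)(F)F)c1`, 1680 nM; compound 2, `CC(CS(=O)(=O)c1ccc(C(F)(F)F)cc1)C(=O)Nc1ccc(C#N)c(C(F)(F)F)c1`, 58000 nM.

Of the compounds shown here, two have been measured in a functional assay on LNCaP cells (Homo sapiens) for antiproliferative activity, read by MTT assay, with a stated time of 96 h; a higher number here means a weaker inhibitor, a lower number a stronger inhibitor. Compound 1 gives 1680 nM. Compound 2 gives 58000 nM, which is the higher of the two numbers; the gap between the two lies beyond the usual scatter, but the two structures differ in more than one place, so the pair shows only its two values and nothing about any single change.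

The next compound, compound 3, `CC(CS(=O)(=O)c1ccc(C(F)(F)F)cc1)C(=O)Nc1ccc([N+](=O)[O-])c(C(F)(F)F)c1`, keeps everything of compound 2 apart from one exchange: nitro in place of cyano on an aromatic carbon. For the measured compounds named here, no measured pair here isolates this exchange, so any expectation rests on compound 2 alone. The step of a 1.0-fold higher number from compound 2 to compound 3 (0.01 log units; within the scatter) is expected to stay within the usual scatter, with no clear direction either way. On that basis compound 3 is estimated to give 60000 nM in this assay, with a likely range from 25000 nM to 150000 nM, which leaves it at the weak end alongside compound 2 until the measurement is made.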

Compound 3, half-maximal inhibitory concentration: 3310 nM
Compound 3: middle estimate off by 18-fold (1.26 log units), on the high side; measured number outside the range, below it.
By their numbers in this assay, from the lowest: compounds 1 and 3 (each within the scatter of the next); then compound 2.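

In this assay, for the compounds shown here, the exchange of cyano for nitro on an aromatic carbon, ortho to a trifluoromethyl group and para to a large group, is the first single change that can be read, and it gives an 18-fold lower number from compound 2 to compound 3 (1.24 log units; beyond the scatter). This shows that the number in this assay depends strongly on which group occupies this position, even with the rest of compound 2 held fixed, so the two groups cannot be treated as interchangeable here. The compounds shown offer no measurement that accounts for the size of this step.

This single pair does not show whether the exchange would have a similar effect in another setting, such as the different side chain of compound 1, which carries two sulfur-linked aryl groups and has no nitro counterpart among the compounds shown. It also leaves open how this position would respond to other groups, such as an amine, a carboxylic acid, a chlorine atom or a longer chain, so only these two groups can be compared here.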